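The source may hold more compounds than are shown below. What is called first, only, known or untested is meant among the compounds shown, and "the series" means these compounds.

Of the compounds shown here, three sharing one core have so far been measured in an assay on cells for displacement of a labelled ligand from corticotropin-releasing factor receptor 1 (Homo sapiens), with a stated time of 100 min; on this read-out higher numbers stand for weaker inhibition and lower numbers for stronger inhibition. Compound 1 `Cc1cc(C)c(-n2c(Cl)cn3c(CN(CCC(F)(F)F)CC4CC4)c(C(F)(F)F)nc23)c(C)c1` gives 16 nM. Compound 2 `CCCCN(C)Cc1c(C(F)(F)F)nc2n(-c3c(C)cc(C)cc3C)c(Cl)cn12` gives 310 nM. Compound 3 `C=C(C)CN(CC)Cc1c(C(F)(F)F)nc2n(-c3c(C)cc(C)cc3C)c(Cl)cn12` gives 67 nM, which places it second highest of the three: one of its two steps is a 4.2-fold higher number from compound 1 to compound 3 (0.62 log units; beyond the scatter), while a 4.6-fold lower number from compound 2 to compound 3 (0.67 log units; beyond the scatter) separates it from compound 2. Every difference among these three sits on the two groups carried by the amine nitrogen, and swapping those groups has moved the numbers by a 19-fold higher number from compound 1 to compound 2 (1.29 log units; beyond the scatter) at most.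

Compound 4 `CCN(Cc1ccc(Cl)c(Cl)c1)Cc1c(C(F)(F)F)nc2n(-c3c(C)cc(C)cc3C)c(Cl)cn12` is the next member. It differs from compound 3 by 3,4-dichlorophenyl in place of 1-methylethenyl on a saturated chain carbon bound to an amine nitrogen. The measured steps bear on this change only loosely: they show that the amine substituents matter, yet none of them introduces a ring of this kind, so they set the scale of what a change here can do without pointing firmly in either direction. The expectation for this assay is therefore a modest shift, a 1.2-fold higher number from compound 3 to compound 4 (0.08 log units; within the scatter), with a wide margin either way. Compound 4 is estimated at 80 nM, in a range from 20 nM to 400 nM.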

Compound 4, inhibition constant: 580 nM
Beside the measured number, compound 4's estimate is 7.3-fold (0.86 log units) below it, outside the stated range (above it).
By their numbers in this assay, from the lowest: compound 1; then compound 3; then compounds 2 and 4 (each within the scatter of the next).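

In this assay, with the ethyl group on the amine nitrogen kept, going from 2-methylprop-2-en-1-yl to 3,4-dichlorobenzyl gives an 8.7-fold higher number from compound 3 to compound 4 (0.94 log units; beyond the scatter) and so weakens inhibition. This is the first look at a six-membered aromatic ring on this saturated chain carbon, and it shows that the position does not readily accept this ring with its two chlorine atoms, since the number for compound 4 lies within the scatter of that for compound 2, among the weakest binders shown here. Nothing available explains why this exchange weakens inhibition.

Among these compounds, the single step changes the ring and the two chlorine atoms together, so a plain benzyl group on the same nitrogen would be needed to tell whether the ring itself or the chlorine atoms account for the loss. Going by these compounds, it also remains open whether 3,4-dichlorobenzyl would behave the same way with the 3,3,3-trifluoropropyl group of compound 1 on the nitrogen in place of ethyl.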